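A few compounds are considered here, and "the series" means these few. Any claim that something is new, unique, unknown or untested is made for them only; others in the source may bear on it.

Three compounds of one shared core have been measured in an assay on ileum for inhibition of Voltage-dependent L-type calcium channel subunit alpha-1C (Cavia porcellus); a lower number here means a stronger inhibitor, a higher number a weaker inhibitor:

compound 1, `CCCOC(=O)C1=C(C)NC(C)=C(C(=O)OCC)C1c1[nH]c(CC)nc1Cl`, gives 0.543 nM
compound 2, `CCOC(=O)C1=C(C)NC(C)=C(C(=O)OC(C)C)C1c1[nH]c(CC)nc1Cl`, gives 0.564 nM
compound 3, `CCOC(=O)C1=C(C)NC(C)=C(C(=O)OCC2CCCCC2)C1c1[nH]c(CC)nc1Cl`, gives 1.07 nM

Compound 3 carries the highest of the three numbers, but only by margins that the assay does not resolve: a 2.0-fold higher number from compound 1 to compound 3 (0.29 log units; within the scatter) and a 1.9-fold higher number from compound 2 to compound 3 (0.28 log units; within the scatter). The three compounds differ from one another solely in the ester group on one side of the core, and the step of a 1.0-fold higher number from compound 1 to compound 2 (0.02 log units; within the scatter) shows that exchanging one small alkyl ester for another leaves the number where it was.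

Compound 4, `CCOC(=O)C1=C(C)NC(C)=C(C(=O)OCc2ccccc2)C1c1[nH]c(CC)nc1Cl`, continues this series at the same place. Relative to compound 3 the difference is phenyl in place of cyclohexyl on a saturated chain carbon bound to an oxygen next to a carbonyl group. All three measured steps bear on it, since each varies the same ester, and none of them moved the number beyond the scatter; the largest, from a small chain to the cyclohexylmethyl ester, was still within it. On that basis no step beyond the scatter is expected in this assay for the change to a benzyl ester, in either direction, and the expected step is a 1.2-fold lower number from compound 3 to compound 4 (0.08 log units; within the scatter). Compound 4 is therefore estimated at 0.9 nM in this assay, with a range from 0.4 nM to 2.2 nM.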

Compound 4, half-maximal inhibitory concentration: 2.66 nM
Beside the measured number, compound 4's estimate is 3.0-fold (0.47 log units) below it, and the stated range ends below it.
By their numbers in this assay, from the lowest: compounds 1, 2 and 3 (each within the scatter of the next); then compound 4.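

In this assay, going by these compounds alone, this ester position is no longer indifferent: the benzyl ester is the first change to move the number beyond the scatter, with a rise (a 2.5-fold higher number from compound 3 to compound 4 (0.40 log units; beyond the scatter)) even though cyclohexyl and phenyl both count 6 heavy atoms (6 carbon) in one six-membered ring and differ only in that ring being aromatic or non-aromatic. The gap is wider against the small alkyl esters (a 4.7-fold higher number from compound 2 to compound 4 (0.67 log units; beyond the scatter); a 4.9-fold higher number from compound 1 to compound 4 (0.69 log units; beyond the scatter)), so compound 4 is the weakest inhibitor of the four, while compounds 1, 2 and 3 remain within the scatter of one another. Nothing available accounts for why the aromatic ring gives the higher number.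

The contrast between the two rings rests on a single pair of compounds, so the compounds shown leave open whether it would hold with a propyl ester rather than an ethyl ester on the other side of the core. They also leave open whether a pyridine ring in place of phenyl, or a phenylethyl ester with its longer chain, would give a number nearer that of the cyclohexylmethyl ester or that of the benzyl ester.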